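Acyclic nucleoside analogues: nitro substitution on compound 2

The source may hold more compounds than are shown below. What is called first, only, known or untested is meant among the compounds shown, and "the series" means these compounds.

Measured so far:
compound 1, `O=c1[nH]c(=O)n(COCCO)cc1[N+](=O)[O-]`: 447 ug/mL
compound 2, `Nc1ccn(COCCO)c(=O)n1`: 675 ug/mL

Two compounds sharing the (2-hydroxyethoxy)methyl side chain have been run in a functional assay on L1210 cells (Mus musculus) for inhibition; on this read-out higher numbers stand for weaker inhibition and lower numbers for stronger inhibition. Compound 1 gives 447 ug/mL and compound 2 gives 675 ug/mL. Compound 2 has the highest of the two numbers, but its nearest neighbour, compound 1, lies within the scatter, so the two are not distinguishable on this read-out; both sit at weak inhibition. Among the compounds with values here, no single-point step between the measured compounds is available.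

The next compound, compound 3, `Nc1nc(=O)n(COCCO)cc1[N+](=O)[O-]`, is derived from compound 2 by the change (nitro in place of hydrogen on an aromatic carbon). Within the data shown here, the only comparison at hand, compound 1 against compound 2, does not separate the two values, so no direction can be read from it. The step of a 1.2-fold lower number from compound 2 to compound 3 (0.09 log units; within the scatter) is therefore expected to be none beyond the scatter. Compound 3 is estimated at 550 ug/mL, with a range from 180 ug/mL to 1700 ug/mL, allowing for the chance that the assay returns only a limit at this weak level of inhibition.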

Compound 3, concentration for 50% inhibition: 71 ug/mL
Estimate against measurement, compound 3: 7.7-fold (0.89 log units) above; measured number outside the range, below it.
By their numbers in this assay, from the lowest: compound 3; then compounds 1 and 2 (each within the scatter of the next).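

In this assay, within the data shown here, the ring carbon ortho to an amino group proves responsive to substitution: nitro in place of hydrogen gives a 9.5-fold lower number from compound 2 to compound 3 (0.98 log units; beyond the scatter), the first separation beyond the scatter and the only single-place step available so far. The nitro group alone does not account for the low number, since compound 1, which also carries a nitro group but has no amino group, gives 447 ug/mL, while compound 3 gives 71 ug/mL, so the result is tied to the nitro group and amino group occurring together on the core of compound 3. No measurement is available that explains the gain at this position.

Open, going by these compounds, is whether the gain is specific to nitro or would also appear with a nitrile, a chlorine atom or a carboxylic acid on the same aromatic carbon. Also open, on these data alone, is whether it persists when the (2-hydroxyethoxy)methyl group is replaced by a longer chain or when the amino group is replaced by a methylamine.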